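A few compounds are considered here, and "the series" means these few. Any claim that something is new, unique, unknown or untested is made for them only; others in the source may bear on it.

Measured in a functional assay (aorta) with Rattus norvegicus as the target; on this read-out higher numbers stand for an effect only at larger amounts of compound and lower numbers for an effect already at smaller amounts:
- compound 1 `COc1ccc(-c2nc(/N=C(\N)NC(C)C)sc2-c2ccc(OC)cc2)cc1`: 9.1 uM
- compound 2 `COc1ccc(-c2nc(/N=C(\N)N3CCOCC3)sc2-c2ccc(OC)cc2)cc1`: 66 uM
- compound 3 `CNC(=O)NCc1nc(-c2ccc(OC)cc2)c(-c2ccc(OC)cc2)s1`: 15 uM

Compound 3 sits at the low end of the three numbers, not alone: a 1.6-fold higher number from compound 1 to compound 3 (0.22 log units; within the scatter), and a 4.4-fold lower number from compound 2 to compound 3 (0.64 log units; beyond the scatter). Compound 4 `COc1ccc(-c2nc(C(=O)N3CCCCC3)sc2-c2ccc(OC)cc2)cc1` differs from it thus: (piperidin-1-yl)carbonyl in place of ((methylcarbamoyl)amino)methyl on an aromatic carbon.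

Both steps at this aromatic carbon bear on the change, and so does a 7.3-fold higher number from compound 1 to compound 2 (0.86 log units; beyond the scatter). Going by the values given here, compound 2, the only measured compound with a six-membered non-aromatic ring there, gives 66 uM. Among the compounds with values here, no measured compound carries (piperidin-1-yl)carbonyl, so the read-across is loose. A modest rise in the number is expected in this assay, the expected move being a 2.0-fold higher number from compound 3 to compound 4 (0.30 log units; within the scatter). Compound 4 is estimated at 30 uM, with an expected range of 9 uM to 100 uM.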

Compound 4, concentration for half-maximal effect: 11 uM
Compound 4: middle estimate off by 2.7-fold (0.44 log units), on the high side; the measured number falls inside the stated range.
By their numbers in this assay, from the lowest: compounds 1, 4 and 3 (each within the scatter of the next); then compound 2.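

In (this assay), (piperidin-1-yl)carbonyl on this aromatic carbon, a group with 0 hydrogen-bond donors, stays level with the two smaller open-chain groups (a 1.4-fold lower number from compound 3 to compound 4 (0.13 log units; within the scatter); a 1.2-fold higher number from compound 1 to compound 4 (0.08 log units; within the scatter)). A six-membered non-aromatic ring at this position therefore does not by itself go with the high number of compound 2 (a 6.0-fold lower number from compound 2 to compound 4 (0.78 log units; beyond the scatter)). Nothing on hand explains the gap between these two ring-bearing groups.

From the compounds shown here alone, whether the carbonyl or the piperidine ring matters more stays open. A (morpholin-4-yl)carbonyl group or an open-chain dimethylamide at this carbon would separate the two.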